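The source may hold more compounds than are shown below. What is called first, only, known or untested is meant among the compounds shown, and "the series" means these compounds.

Of the compounds shown here, three sharing one core have been measured so far in a functional assay on DU-145 cells (Homo sapiens) for antiproliferative activity, read by sulforhodamine B assay, with a stated time of 48 h (a lower number here means a stronger inhibitor, a higher number a weaker inhibitor), to date. Compound 1 (`COc1ccc(-c2oc3c(OC)c(OC)cc(OCCCC(=O)N4CCN(C)CC4)c3c(=O)c2O)cc1`) gives > 40000 nM as a limit of the assay and not a number. Compound 2 (`COc1ccc(-c2oc3c(OC)c(OC)cc(OCCCCC(=O)N4CCN(C)CC4)c3c(=O)c2O)cc1`) likewise gives > 40000 nM as a limit. For the measured compounds named here, compound 3 (`CCCCCN(C)C(=O)CCCCCOc1cc(OC)c(OC)c2oc(-c3ccc(OC)cc3)c(O)c(=O)c12`) gives 22500 nM as the only actual number in the set. Against that number stands the limit of > 40000 nM in this assay, at which 2 of the 3 values shown sit, and nothing else.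

Compound 4 (`COc1ccc(-c2oc3c(OC)c(OC)cc(OCCCCCC(=O)NCc4ccccn4)c3c(=O)c2O)cc1`) differs from compound 3 on a carbonyl carbon, where ((pyridin-2-yl)methyl)amino in place of methyl(pentyl)amino on a carbonyl carbon is the whole change. The nearest measured steps are an at least 1.7-fold lower number from compound 1 to compound 3 (0.24 log units; that floor lies within the scatter) and an at least 1.7-fold lower number from compound 2 to compound 3 (0.24 log units; that floor lies within the scatter) and both give only floors, while a step that the two limits leave unreadable from compound 1 to compound 2 has no readable size. None of these steps brings in ((pyridin-2-yl)methyl)amino, so no change beyond the scatter is expected in this assay for this swap. The expected step is a 1.1-fold higher number from compound 3 to compound 4 (0.05 log units; within the scatter) and it stays within that scatter. Compound 4 is estimated at 25000 nM with an expected range from 9000 nM to 40000 nM in this test.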

Compound 4, half-maximal inhibitory concentration: > 40000 nM
Compound 4: no number, only a limit; the forecaster's own chance of this, stated with the estimate: 35%; middle value at least 1.6-fold (0.20 log units) from the limit.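

Putting ((pyridin-2-yl)methyl)amino in place of methyl(pentyl)amino on a carbonyl carbon gives, in this assay, an at least 1.7-fold higher number from compound 3 to compound 4 (0.24 log units; that floor lies within the scatter), so this change can be read only as a floor. Compound 4 gives a limit and not a number, and methyl(pentyl)amino remains the only group on this carbonyl carbon shown with a number: the limit of > 40000 nM in this assay, at which 3 of the 4 values shown sit. The steps from compound 1 and compound 2 to compound 4 cannot be read, since both ends of each are limits.

From the compounds shown here alone, how far the true value of compound 4 lies past its limit stays open, and with it the real size of the step. Also open, going by these compounds, is whether benzylamino, which carries a phenyl ring in place of the pyridine, or a simple dimethylamino on this carbonyl carbon would give a number.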